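Phenyl in place of cyclopropyl: an expected gain

A few compounds are considered here, and "the series" means these few. Any claim that something is new, unique, unknown or untested is made for them only; others in the source may bear on it.

In an assay on isolated protein for inhibition of Nitric oxide synthase, inducible (Homo sapiens), with a stated time of 30 min, tested at 1 mM (on this read-out lower numbers stand for less inhibition and higher numbers for more inhibition at the one concentration tested (going by the name of the read-out)), three compounds have been measured:
compound 1, `Nc1cc(Cl)c(Cl)cc1C1=NN(C(=O)C2CC2)CC1`, gives 15.5%;
compound 2, `Nc1cc(Cl)c(Cl)cc1C1=NN(C(=O)c2ccccc2)CC1`, gives 36.1%;
compound 3, `Nc1ccccc1C1=NN(C(=O)C2CC2)CC1`, gives 14.8%.

Compound 2 differs from compound 1 by phenyl in place of cyclopropyl on a carbonyl carbon, and that change made the step of a number 20.6 percentage points higher from compound 1 to compound 2 (beyond the scatter). Compound 4, `Nc1ccccc1C1=NN(C(=O)c2ccccc2)CC1`, differs from compound 3 by phenyl in place of cyclopropyl on a carbonyl carbon. The place is the same word for word in both pairs, so this is the same change, and it occurs twice among the compounds shown. How the core of compound 3 differs from the core of compound 1 is not broken down here; in this assay the two lie within the scatter of each other. The step from compound 3 to compound 4 in this assay is expected to be about as large as the earlier one, a number 20.2 percentage points higher from compound 3 to compound 4 (beyond the scatter). That expectation rests on compound 1, which gave 15.5%, standing within the scatter of compound 3. Compound 4 is therefore estimated at 35%, expected to fall between 22% and 48%.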

Compound 4, a percentage reported as inhibition, at one concentration (the size of the read-out at that concentration, not a potency): 8.7%
Estimate against measurement, compound 4: 26.3 percentage points above; the measured number lies below the stated range.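

In this assay, phenyl in place of cyclopropyl on a carbonyl carbon gave a number 6.1 percentage points lower from compound 3 to compound 4 (within the scatter), so the gain seen on the core of compound 1 did not appear on the core of compound 3. The two steps do not agree: the same change on two cores in this assay, a number 20.6 percentage points higher (beyond the scatter) from compound 1 to compound 2 and a number 6.1 percentage points lower (within the scatter) from compound 3 to compound 4, 26.7 percentage points apart, beyond the scatter of two such steps. This shows that, for these two pairs, the outcome of the change was not the same on both cores, but it does not show which difference between the cores matters, and two pairs give no rule for any further core.

The compounds shown leave open how either core would respond to another group on the carbonyl carbon, such as a longer chain or an amine. They also leave open whether the change would behave the same way on any third core.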